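Phenyl in place of cycloheptyl on the amide-type nitrogen

This account rests on a few compounds, and the source may have more. Where it says the series, first, only, none or still open, it means among the compounds named here.

Among the measured compounds shown here, in an ADME assay on MRC5 cells (Homo sapiens) for inhibition, with a stated time of 72 h (on this read-out lower numbers stand for an effect already at smaller amounts and higher numbers for an effect only at larger amounts of compound), compound 3 (`COc1cccc(OC)c1C(=O)Nc1c[nH]nc1C(=O)NC1CCCCCC1`) gives 42000 nM and is the only member of the series with an actual number so far. Compound 1 (`COc1cccc(OC)c1C(=O)Nc1c[nH]nc1C(=O)NC1CCC1`) reads > 50000 nM and that value is a limit of the assay. Compound 2 (`COc1cccc(OC)c1C(=O)Nc1c[nH]nc1C(=O)NCC1CCCCC1`) reads > 50000 nM and that value is also a limit. The data are thus dominated by the limit of > 50000 nM in this assay, at which 2 of the 3 values shown sit, and offer little else to work with.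

Compound 4 (`COc1cccc(OC)c1C(=O)Nc1c[nH]nc1C(=O)Nc1ccccc1`) carries phenyl in place of cycloheptyl on the amide-type nitrogen (counted: phenyl in place of cycloheptyl on an amide-type nitrogen). For the measured compounds named here, the steps that bear on this change are those at the same nitrogen: an at least 1.1-fold lower number from compound 1 to compound 3 (0.07 log units; that floor lies within the scatter) and an at least 1.1-fold lower number from compound 2 to compound 3 (0.07 log units; that floor lies within the scatter) alongside a step that the two limits leave unreadable from compound 1 to compound 2 as the third. None of them shows a size beyond the scatter, and no aromatic group at this nitrogen has been measured yet.

The expected step in this assay is a 1.1-fold lower number from compound 3 to compound 4 (0.02 log units; within the scatter) and nothing beyond the scatter is expected, with a fair chance of another limit. For compound 4 the estimated value is 40000 nM with an expected range from 15000 nM to 60000 nM in this series.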

Compound 4, half-maximal effective concentration: > 50000 nM
Compound 4 was reported as a limit; the forecaster's own chance of this, stated with the estimate: 55%; middle value at least 1.2-fold (0.09 log units) from the limit.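

Compound 4 brings the first aromatic group onto the amide-type nitrogen in this assay, and its reading is a limit of the assay, not a number. Among the compounds shown here, the only readable step is an at least 1.1-fold higher number from compound 3 to compound 4 (0.07 log units; that floor lies within the scatter); the steps to compound 4 from the two other compounds with limits cannot be read. An anilino group thus gives no number at this position, and compound 3 remains the only compound with a measured value, so this change adds one more compound to the same ceiling: the limit of > 50000 nM in this assay, at which 3 of the 4 values shown sit.

The compounds shown leave open how a piperidine, a carboxylic acid or a longer alkyl chain on this nitrogen would read, and whether any group there gives a number clearly away from the limit. As far as these compounds go, how far changes to the shared core would move the read-out also remains open.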